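Replacing the 3-chlorophenyl of compound 3 with 2-methoxyphenyl

The compounds below may be only part of what the source reports. "The series", "measured", "known", "first", "only" and "open" are said of these compounds alone.

The three measured compounds share one core and differ only in the group on the saturated chain carbon bound to an aromatic nitrogen. Compound 3 `CCCn1c(=O)c2nc(-c3cnn(Cc4cccc(Cl)c4)c3)[nH]c2n(CCC)c1=O` gives 18 nM in an in vitro assay on HEK293 cells for displacement of a labelled ligand from adenosine receptor A2b (Homo sapiens); a lower number here means a stronger inhibitor, a higher number a weaker inhibitor. Compound 2 `CCCn1c(=O)c2[nH]c(-c3cnn(Cc4ccccc4)c3)nc2n(CCC)c1=O` gives 11 nM, a value that lies within the scatter of compound 3. Compound 1 `CCCn1c(=O)c2nc(-c3cnn(Cc4c(F)cccc4F)c3)[nH]c2n(CCC)c1=O`, which carries 2,6-difluorophenyl, gives 390 nM, far weaker than either. Within the data shown here, the one step that touches compound 3 directly is a 22-fold lower number from compound 1 to compound 3 (1.34 log units; beyond the scatter).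

Compound 4 `CCCn1c(=O)c2nc(-c3cnn(Cc4ccccc4OC)c3)[nH]c2n(CCC)c1=O` is not yet measured. Its change from compound 3 is 2-methoxyphenyl in place of 3-chlorophenyl on a saturated chain carbon bound to an aromatic nitrogen. Among the measured compounds shown here, no measured pair shows a methoxy group on this phenyl ring, so the step can only be judged from the spread among compounds 1, 2 and 3: the phenyl and 3-chlorophenyl analogues sit close together, while the 2,6-difluorophenyl analogue sits much higher. For the measured compounds named here, a group other than hydrogen or chlorine on this ring has therefore only one precedent, and that one was unfavourable. The step of a 2.2-fold higher number from compound 3 to compound 4 (0.35 log units; beyond the scatter) is expected to be small and toward a higher number, close to the edge of the scatter. Compound 4 is estimated to give 40 nM, within the range 12 nM to 130 nM.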

Compound 4, inhibition constant: 37 nM
Beside the measured number, compound 4's estimate is 1.1-fold (0.03 log units) above it; low and high end bracket the measured number.
By their numbers in this assay, from the lowest: compounds 2 and 3 (each within the scatter of the next); then compound 4; then compound 1.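

In this assay the 2-methoxyphenyl group costs far less than the only earlier ring with a group other than chlorine: a 2.1-fold higher number from compound 3 to compound 4 (0.31 log units; beyond the scatter) is a modest step, while an 11-fold lower number from compound 1 to compound 4 (1.02 log units; beyond the scatter) is a large one. This position therefore accepts a methoxy-bearing ring with only a modest loss against 3-chlorophenyl, and the steep loss seen with 2,6-difluorophenyl does not extend to every ring with a group at its 2 position, so compound 1 no longer stands for all such rings. Nothing available explains why 2-methoxyphenyl and 2,6-difluorophenyl differ so much here.

The step from 3-chlorophenyl to 2-methoxyphenyl changes both the group and its place on the ring at once, so the compounds shown cannot divide the modest loss between the two; 3-methoxyphenyl and 2-chlorophenyl would be the pair to separate them. From the compounds shown here alone, it also remains open whether this position would accept a ring bearing an amine or a carboxylic acid, or a longer chain in place of the methoxy group.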